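A few compounds are considered here, and "the series" means these few. Any claim that something is new, unique, unknown or untested is made for them only; others in the source may bear on it.

Compound 1 `Cc1nc2c3ccccc3ccc2c2nc3c(ccc4ccccc43)c(-c3cccc([N+](=O)[O-])c3)c12`: 117 ug/mL
Compound 2 `Cc1nc2c3ccccc3ccc2c2nc3c(ccc4ccccc43)c(-c3cccnc3)c12`: 98.2 ug/mL
Compound 3 `COc1ccc(-c2c3ccc4ccccc4c3nc3c2c(C)nc2c4ccccc4ccc32)cc1`: 133 ug/mL

All three compounds were measured in a functional assay, read by spectrophotometry, with a stated time of 30 min (a higher number here means a weaker inhibitor, a lower number a stronger inhibitor), and differ only in one aromatic group on the shared core. Compound 3, at 133 ug/mL, cannot be separated from the other two, since a 1.1-fold higher number from compound 1 to compound 3 (0.06 log units; within the scatter) and a 1.4-fold higher number from compound 2 to compound 3 (0.13 log units; within the scatter). Compound 4 `Cc1nc2c3ccccc3ccc2c2nc3c(ccc4ccccc43)c(-c3cc([N+](=O)[O-])ccc3N)c12` keeps the core of compound 3 and changes that same group: 2-amino-5-nitrophenyl in place of 4-methoxyphenyl on an aromatic carbon. In words, 2-amino-5-nitrophenyl stands in place of 4-methoxyphenyl on an aromatic carbon, opposite the ring nitrogen.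

For the measured compounds named here, all the measured steps bear on this site, and none of them leaves the scatter. Besides the two steps to compound 3, a 1.2-fold lower number from compound 1 to compound 2 (0.08 log units; within the scatter). Going by the values given here, the closest precedent is compound 1, whose 3-nitrophenyl also carries a nitro group and which gives 117 ug/mL. Among the compounds with values here, no measured compound has an amino group on this ring, so that part of the change is untested, and the range must stay wide. No step beyond the scatter is expected, and the estimated step is small: a 1.2-fold lower number from compound 3 to compound 4 (0.08 log units; within the scatter). The expected value for compound 4 is 110 ug/mL, with an estimated range from 55 ug/mL to 220 ug/mL.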

Compound 4, half-maximal inhibitory concentration: 93.1 ug/mL
Estimate against measurement, compound 4: 1.2-fold (0.07 log units) above; measured number inside the range.
By their numbers in this assay, from the lowest: compounds 4, 2, 1 and 3 (each within the scatter of the next).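

In this assay, for the compounds shown here, amino in place of hydrogen on the aromatic ring at this position gives a 1.3-fold lower number from compound 1 to compound 4 (0.10 log units; within the scatter), so the amino group, untested on this ring in the earlier compounds, has no effect here that can be told from the scatter. The 2-amino-5-nitrophenyl group has 10 heavy atoms against 8 for 4-methoxyphenyl, yet the result is a 1.4-fold lower number from compound 3 to compound 4 (0.15 log units; within the scatter), and against pyridin-3-yl it is a 1.1-fold lower number from compound 2 to compound 4 (0.02 log units; within the scatter), so all four groups at this site, now including one with a hydrogen-bond donor, remain indistinguishable in this assay. No available evidence accounts for how closely these numbers sit.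

The compounds shown leave open whether any group at this position can move the number beyond the scatter, since each one places a six-membered aromatic ring there, and a carboxylic acid on that ring, a piperidine or a plain hydrogen in its place would test this more sharply. They also leave open what an amino group does on this ring without the nitro group, as in 2-aminophenyl, and what happens when the methyl on the shared core gives way to a longer chain.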